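Nitrothiophene and quinoline acyl-isothiourea series: growth inhibition notes

The compounds below may be only part of what the source reports. "The series", "measured", "known", "first", "only" and "open" are said of these compounds alone.

Measured compounds and values:
compound 1 `CS/C(=N\C(=O)c1csc([N+](=O)[O-])c1)NC(=O)c1csc([N+](=O)[O-])c1` gives > 100000 nM
compound 2 `O=C(/N=C(/NC(=O)c1csc([N+](=O)[O-])c1)[Se]Cc1ccccc1)c1csc([N+](=O)[O-])c1` gives > 100000 nM
compound 3 `CS/C(=N\C(=O)c1cnc2ccccc2c1)NC(=O)c1cnc2ccccc2c1` gives > 100000 nM

All three values come from a functional assay on HT-29 cells (Homo sapiens) for cytotoxicity, read by MTT assay, with a stated time of 72 h; a lower number here means a stronger inhibitor of growth, a higher number a weaker inhibitor of growth. The value for compound 1 is a limit of the assay, not a number. The value for compound 2 is likewise a limit. The value for compound 3 is also a limit. The step that the two limits leave unreadable from compound 1 to compound 2 is therefore not readable, since both ends sit at the limit; the change made is a group of 8 heavy atoms (7 carbon, 1 selenium; one six-membered aromatic ring of carbon only) in place of a group of 2 heavy atoms (1 carbon, 1 sulfur; no ring), on a carbon with a double bond to nitrogen. Compound 3 carries a different core from compound 1, and the difference between the two cores is not broken down here.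

Compound 4 `O=C(/N=C(/NC(=O)c1cnc2ccccc2c1)[Se]Cc1ccccc1)c1cnc2ccccc2c1` has not yet been measured in this assay. It differs from compound 3 by a group of 8 heavy atoms (7 carbon, 1 selenium; one six-membered aromatic ring of carbon only) in place of a group of 2 heavy atoms (1 carbon, 1 sulfur; no ring), on a carbon with a double bond to nitrogen, the same change that separates compound 1 from compound 2, made at the same place. Going by the values given here, the only evidence bearing on this change is the limit of > 100000 nM in this assay, at which 3 of the 3 values shown sit, which gives no readable direction or size. Because the step that the two limits leave unreadable from compound 1 to compound 2 stays unreadable within the nitrothiophene pair, the expectation for the quinoline pair can only be that the change leaves the value where compound 3 stands, so compound 4 is expected to give 100000 nM. The estimated range for compound 4 runs from 30000 nM to 300000 nM. The expected step of a number no higher from compound 3 to compound 4 (the limit leaves the size open) is thus close to none, with a high chance that only a limit is reported again.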

Compound 4, concentration for total growth inhibition: > 100000 nM
Compound 4 was reported as a limit; the forecaster's own chance of this, stated with the estimate: 85%; the middle value sits exactly at the limit.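

Compound 3 and compound 4 both stand at a limit of the assay rather than at a number, so in this assay no step can be read between them, and the same holds for compound 1 and compound 2: the limit of > 100000 nM in this assay, at which 4 of the 4 values shown sit. The compounds shown leave open whether any of them inhibits growth at a readable concentration, and how the methylsulfanyl group compares with the group replacing it.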